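Removing a Methyl From the Fused Ring of Compound 3

The source may report more compounds than this note shows. Statements on the series, on what has been measured and on what is new or still open speak of the compounds shown alone.

Measured compounds:
compound 1 `Clc1ccc(COc2ccccc2/C=C/C(/C=C/c2ccccn2)=N/Oc2ncnc3cc(Cl)ccc23)c(Cl)c1` 23.6%
compound 2 `Clc1ccc(COc2ccc(/C=C/C(/C=C/c3ccccn3)=N/Oc3ncnc4ccccc34)cc2)cc1` 91.2%
compound 3 `Cc1cccc(COc2ccc(/C=C/C(/C=C/c3ccccn3)=N/Oc3ncnc4cccc(C)c34)cc2)c1` 93.4%

Of the compounds shown here, three sharing one core have been tested in a functional assay on SMMC-7721 cells (Homo sapiens) for inhibition, read by MTT assay, with a stated time of 72 h, tested at 1 uM; a lower number here means a weaker effect, a higher number a stronger effect of the compound at the concentration tested. Compound 1 gives 23.6%, compound 2 gives 91.2% and compound 3 gives 93.4%. Compound 3 thus shows the highest number of the three, but its gap to compound 2 lies within the scatter, so the two cannot be told apart; only compound 1 stands clearly apart, with a much lower number.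

Compound 4 `Cc1cccc(COc2ccc(/C=C/C(/C=C/c3ccccn3)=N/Oc3ncnc4ccccc34)cc2)c1` has not yet been measured. It differs from compound 3 in one place: hydrogen in place of methyl on an aromatic carbon. Put another way, the 5-methylquinazolin-4-yl group becomes a quinazolin-4-yl group.

Going by the values given here, no pair of measured compounds differs in just one place, so no step of exactly this kind has been seen. What the numbers do show is that compound 2, which also carries a quinazolin-4-yl group without a methyl, gives 91.2%, close to compound 3. On that basis compound 4 is expected to stay near compound 3, with the step of a number 5.4 percentage points lower from compound 3 to compound 4 (within the scatter) expected to be none beyond the scatter. The estimate for compound 4 is 88%, between 70% and 97%.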

Compound 4, a percentage reported as inhibition, at one concentration (the size of the read-out at that concentration, not a potency): 69.2%
The estimate for compound 4 lay 18.8 percentage points above the measured number, outside the stated range (below it).
By their numbers in this assay, from the lowest: compound 1; then compound 4; then compounds 2 and 3 (each within the scatter of the next).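

In this assay, replacing the methyl of the 5-methylquinazolin-4-yl group with hydrogen gives a number 24.2 percentage points lower from compound 3 to compound 4 (beyond the scatter), so this small change on the aromatic carbon of the fused ring has a clear effect when the 3-methylphenyl group stays in place. The second step, with the quinazolin-4-yl group held constant, is a number 22 percentage points lower from compound 2 to compound 4 (beyond the scatter) and comes from having 3-methylphenyl in place of 4-chlorophenyl, which shows that this distant part of the molecule also affects the read-out. No available evidence explains either drop.

From the compounds shown here alone, what remains open is whether the methyl matters in the same way when 4-chlorophenyl is present, since only the pairing with 3-methylphenyl can be read here. Going by these compounds, it is also open whether an ethyl, a methoxy or an amine on the same aromatic carbon would behave like the methyl or like hydrogen.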